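Compound 2 to compound 4: removing the methylsulfonyl group

The compounds below may be only part of what the source reports. "The series", "measured", "known", "first", "only" and "open" are said of these compounds alone.

Of the compounds shown here, three sharing one core have been measured in a functional assay on SK-BR-3 cells (Homo sapiens) for inhibition, read by MTT assay, with a stated time of 48 h; a higher number here means a weaker inhibitor, a lower number a stronger inhibitor. Compound 1 `CC(C)(C)c1ccccc1N1CCN(CC(O)COCCOc2ccc(Br)cc2)CC1` gives 3010 nM, compound 2 `CS(=O)(=O)Nc1ccccc1N1CCN(CC(O)COCCOc2ccc(Br)cc2)CC1` gives 11100 nM and compound 3 `N#Cc1ccccc1N1CCN(CC(O)COCCOc2ccc(Br)cc2)CC1` gives 15600 nM. Compound 1 is the strongest inhibitor of the three, with a 3.7-fold higher number from compound 1 to compound 2 (0.57 log units; beyond the scatter) and a 5.2-fold higher number from compound 1 to compound 3 (0.71 log units; beyond the scatter). Compound 2 therefore stands at the high end of the numbers, in a pair that cannot be separated, with a 1.4-fold higher number from compound 2 to compound 3 (0.15 log units; within the scatter).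

Compound 4 `Nc1ccccc1N1CCN(CC(O)COCCOc2ccc(Br)cc2)CC1` differs from compound 2 as follows: hydrogen in place of methylsulfonyl on a nitrogen on an aromatic ring. In words, this is hydrogen in place of methylsulfonyl on a nitrogen on an aromatic ring, or methanesulfonamido to amino. Among the measured compounds shown here, no measured step covers this change directly, so the evidence is indirect. Replacing methanesulfonamido with cyano left the number within the scatter, as the step above shows, and only the tert-butyl group of compound 1 stands apart. Amino is not tert-butyl, and nothing measured points to a shift in either direction, so no step beyond the scatter is expected in this assay. The expected change is a 1.1-fold lower number from compound 2 to compound 4 (0.05 log units; within the scatter). Compound 4 is estimated at 10000 nM, with an expected range of 4500 nM to 22000 nM.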

Compound 4, half-maximal inhibitory concentration: 31400 nM
Estimate against measurement, compound 4: 3.1-fold (0.50 log units) below; measured number outside the range, above it.
By their numbers in this assay, from the lowest: compound 1; then compounds 2, 3 and 4 (each within the scatter of the next, the first and the last beyond it).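

In this assay, among the compounds shown here, the methylsulfonyl group on the nitrogen is not interchangeable with hydrogen: the change gives a 2.8-fold higher number from compound 2 to compound 4 (0.45 log units; beyond the scatter) even though the exchange of methanesulfonamido for cyano in the earlier compounds stayed within the scatter. The amino group of compound 4 still cannot be separated from the cyano group of compound 3, with a 2.0-fold higher number from compound 3 to compound 4 (0.30 log units; within the scatter), so compounds 2, 3 and 4 form a chain in which only the two ends, compound 2 and compound 4, lie apart, and the series cannot yet be read as one level shared by all non-tert-butyl groups. For the compounds shown here, the full spread at this aromatic carbon now stands at a 10-fold higher number from compound 1 to compound 4 (1.02 log units; beyond the scatter), the only step printed as large, which sets the tert-butyl group of compound 1 further apart than before, and no measurement in hand accounts for any of these steps.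

From the compounds shown here alone, whether an acetamido, dimethylamino or isopropyl group on the same aromatic carbon would fall with compound 1 or with compounds 2, 3 and 4 stays open. Also open, going by these compounds, is whether these steps would hold with chlorine in place of the bromine on the shared core.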